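A few compounds are considered here, and "the series" means these few. Any claim that something is new, unique, unknown or untested is made for them only; others in the source may bear on it.

Measured so far in an ADME assay on Vero cells (Chlorocebus sabaeus) for cytotoxicity, read by neutral red uptake, tested at 49 ug/mL; a higher number here means a weaker effect of the compound at the concentration tested, a lower number a stronger effect:

- compound 1 `O=C1CSC(c2cccc(F)c2)N1CCN1CCCCC1`: 97%
- compound 2 `O=C1CSC(c2c(Cl)cccc2Cl)N1CCN1CCCCC1`: 100%
- compound 3 `O=C1CSC(c2ccc([N+](=O)[O-])cc2)N1CCN1CCCCC1`: 100%

All three share the same core and the same piperidine-bearing chain on the ring nitrogen; they differ only in the substituent on the phenyl ring. In this assay compound 3 gives 100%, a number level with that of compound 2 at the digits reported, and the two together are the largest numbers of the three. Compound 1 gives 97%, and the gap between compound 1 and compound 3 stays within the usual scatter of this kind of measurement, so no ordering among the three is supported. In effect every substituent tried so far leaves the read-out close to the top of the scale, meaning little effect at the concentration tested.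

Compound 4 `Cc1ccc(C2SCC(=O)N2CCN2CCCCC2)cc1`, not yet measured, differs from compound 3 by methyl in place of nitro on an aromatic carbon.

Within the data shown here, no step between measured compounds is available to calibrate this change. Given that fluoro, dichloro and nitro substitution on the phenyl ring all sit within the scatter of one another in this assay, nothing in the series points to a move beyond the scatter for compound 4, in either direction. For compound 4 the expected value in this assay is 98%, with a range from 90% to 100%. The step that this estimate implies, a number 2 percentage points lower from compound 3 to compound 4 (within the scatter), is expected to lie within the scatter.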

Compound 4, a percentage reported as activity, at one concentration (the size of the read-out at that concentration, not a potency): 100%
Beside the measured number, compound 4's estimate is 2 percentage points below it; low and high end bracket the measured number.
By their numbers in this assay, from the lowest: compounds 1, 2, 3 and 4 (each within the scatter of the next).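

In this assay, among these compounds, methyl in place of nitro on an aromatic carbon, para to a large group, gives no change at the digits printed from compound 3 to compound 4 (within the scatter), the first step that can be read at this position of the series. Two substituents that differ in size and atoms therefore leave the read-out unmoved here, with compound 4 at 100%, close to the top of the scale and so showing little effect at the concentration tested. The second step, 4-methylphenyl in place of 3-fluorophenyl on a saturated ring carbon, gives a number 3 percentage points higher from compound 1 to compound 4 (within the scatter), and no measured evidence bears on why these steps stay so small.

The compounds shown leave open whether an amine or a carboxylic acid on the phenyl ring would move this read-out beyond the scatter, in either direction. They also leave open what a morpholine in place of the piperidine would do, as all four compounds carry the same piperidine-bearing chain on the ring nitrogen.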